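A Naphthalenylcarbonyl Group Enters the Sulfur Chain

The source may report more compounds than this note shows. Statements on the series, on what has been measured and on what is new or still open speak of the compounds shown alone.

Compound 3 `COc1cc(-c2nnc(SC)n2-c2ccc(N(C)C)cc2)cc(OC)c1OC` gives only a limit in a functional assay on HepG2 cells (Homo sapiens) for inhibition, read by MTT assay, with a stated time of 48 h; a lower number here means a stronger inhibitor, a higher number a weaker inhibitor: its reading of > 60000 nM is a limit of the assay, not a number. Compound 1 `COc1ccc(-n2c(SC)nnc2-c2cc(OC)c(OC)c(OC)c2)cc1` likewise stops at > 60000 nM, again a limit. Compound 2 `COc1ccc(-n2c(SCC(=O)c3ccc(F)cc3)nnc2-c2cc(OC)c(OC)c(OC)c2)cc1`, carrying a (4-fluorophenyl)carbonyl on the saturated chain carbon bound to a sulfur, gives 10700 nM. That gives the step of an at least 5.6-fold lower number from compound 1 to compound 2 (0.74 log units; beyond the scatter), while the step that the two limits leave unreadable from compound 1 to compound 3 cannot be read (the limit of > 60000 nM in this assay, at which 2 of the 3 values shown sit). Compound 4 `COc1cc(-c2nnc(SCC(=O)c3ccc4ccccc4c3)n2-c2ccc(N(C)C)cc2)cc(OC)c1OC` differs from compound 3 by (naphthalen-2-yl)carbonyl in place of hydrogen on a saturated chain carbon bound to a sulfur, a change of the same kind as that from compound 1 to compound 2. A similar drop is therefore expected, roughly an at least 5.0-fold lower number from compound 3 to compound 4 (0.69 log units; beyond the scatter). Compound 4 is estimated at 12000 nM, expected to lie between 3000 nM and 60000 nM.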

Compound 4, half-maximal inhibitory concentration: > 60000 nM
Compound 4: a limit, no number; the forecaster's own chance of this, stated with the estimate: 25%; middle value at least 5.0-fold (0.69 log units) away from the limit.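

The step from compound 3 to compound 4 cannot be read, since both readings are limits of the assay, not numbers: the limit of > 60000 nM in this assay, at which 3 of the 4 values shown sit.

The compounds shown leave open whether (naphthalen-2-yl)carbonyl on this sulfur chain changes inhibition at all in this assay.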